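Alkynyl uracils with a phthalimide-butenyl arm: antiproliferative series

The compounds below may be only part of what the source reports. "The series", "measured", "known", "first", "only" and "open" are said of these compounds alone.

Measured in a functional assay on HepG2 cells (Homo sapiens) for antiproliferative activity, read by MTT assay, with a stated time of 3 days; on this read-out higher numbers stand for weaker inhibition and lower numbers for stronger inhibition:
- compound 1, `Cc1ccc(C#Cc2cn(C/C=C\CN3C(=O)c4ccccc4C3=O)c(=O)[nH]c2=O)cc1`: 68000 nM
- compound 2, `CCCCCCC#Cc1cn(C/C=C/CN2C(=O)c3ccccc3C2=O)c(=O)[nH]c1=O`: 14000 nM

Compound 2 holds the lowest number of the two in this assay; the nearest, compound 1, sits at a higher number, and that gap lies beyond the usual scatter. Compound 1 and compound 2 differ in more than one place, so the two values show only that much and no single step can be read from them.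

The next compound, compound 3, `CCCCCc1ccc(C#Cc2cn(C/C=C/CN3C(=O)c4ccccc4C3=O)c(=O)[nH]c2=O)cc1`, is taken from compound 2 by one change: 4-pentylphenyl in place of hexyl on a triple-bonded carbon. Within the data shown here, no measured pair covers this exchange, so the size of the step is open. The expectation is a move of a 1.6-fold lower number from compound 2 to compound 3 (0.19 log units; within the scatter) in this assay, that is a small shift toward a lower number, at the edge of the scatter. Compound 3 is accordingly estimated at 9000 nM, with a range from 3000 nM to 35000 nM, before the measurement is known.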

Compound 3, half-maximal inhibitory concentration: 4300 nM
The estimate for compound 3 lay 2.1-fold (0.32 log units) above the measured number; low and high end bracket the measured number.
By their numbers in this assay, from the lowest: compound 3; then compound 2; then compound 1.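

In this assay, 4-pentylphenyl in place of hexyl on a triple-bonded carbon gives a 3.3-fold lower number from compound 2 to compound 3 (0.51 log units; beyond the scatter), a modest step beyond the scatter and the first single-place step the series offers. This position therefore accepts a six-membered aromatic ring of carbon only, with 11 heavy atoms in place of 6, and the number still falls rather than rises. The compounds shown offer no measurement that explains the step.

Open, from the compounds shown here alone, is whether the step belongs to the aromatic ring or to the larger carbon count, which a plain phenyl or a longer chain such as octyl at this position would help to separate. Also open, going by these compounds, is how an amine or a carboxylic acid at the end of the pentyl chain would read in this assay.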